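This account rests on a few compounds, and the source may have more. Where it says the series, first, only, none or still open, it means among the compounds named here.

Measured compounds:
compound 1, `Cc1ccc(C)c(C(=O)/C=C/C(=O)O)c1`: 5900 nM
compound 2, `CCc1ccc(C(=O)/C=C/C(=O)O)cc1`: 5530 nM

Of the compounds shown here, two of the shared core have been measured in a functional assay on K562 cells (Homo sapiens) for inhibition, read by MTT assay, with a stated time of 72 h; a higher number here means a weaker inhibitor, a lower number a stronger inhibitor. Compound 1 gives 5900 nM in this assay, and compound 2 gives 5530 nM; the two numbers lie within the usual scatter of each other, so neither can be called apart from the other. Compound 3, `Cc1cc(C2CCCCC2)c(C)cc1C(=O)/C=C/C(=O)O`, has not yet been measured. It differs from compound 1 in one place: cyclohexyl in place of hydrogen on an aromatic carbon. Among the compounds with values here, no step between measured compounds involves this kind of change, so there is nothing in the present numbers from which its size can be read off. An account based on compound 1 alone can only offer an expectation: a modest step, expected as a 2.0-fold lower number from compound 1 to compound 3 (0.29 log units; within the scatter), toward a lower number, though a result no further from compound 1 than the scatter would not be surprising. Compound 3 is accordingly estimated at 3000 nM in this assay, with a range from 1000 nM to 9000 nM.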

Compound 3, half-maximal inhibitory concentration: 4240 nM
Compound 3: middle estimate off by 1.4-fold (0.15 log units), on the low side, and the stated range covers the measured number.
By their numbers in this assay, from the lowest: compounds 3, 2 and 1 (each within the scatter of the next).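

In this assay the change gives a 1.4-fold lower number from compound 1 to compound 3 (0.14 log units; within the scatter) and so does not separate the two compounds. Within the data shown here, this shows that the aromatic carbon para to the (2-carboxyethenyl)carbonyl group and ortho to a methyl group can carry cyclohexyl in place of hydrogen without the number leaving the scatter around compound 1, a point the earlier compounds could not address. Nothing available explains the size of this step.

The compounds shown leave open whether another group at this position, such as an amine, a hydroxyl group or a phenyl ring, would move the number beyond the scatter. They also leave open whether cyclohexyl would give a similar step on a core lacking the two methyl groups.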